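A few compounds are considered here, and "the series" means these few. Any claim that something is new, unique, unknown or untested is made for them only; others in the source may bear on it.

In a functional assay on CHO-K1 cells (Cricetulus griseus) for inhibition, read by sulforhodamine B assay, with a stated time of 72 h (a higher number here means a weaker inhibitor, a lower number a stronger inhibitor), three related compounds have been tested so far, and none has given a measured number. Compound 1 `COc1cc(/C=C/C(=O)/C=C(/C=C/c2ccc(OC(C)=O)c(OC)c2)NC2CCCCC2)ccc1OC(C)=O` gives > 25000 nM, which is a limit of the assay and not a number. Compound 2 `CCCNC(=C\C(=O)/C=C/c1ccc(O)c(OC)c1)/C=C/c1ccc(O)c(OC)c1` gives > 25000 nM, again a limit. Compound 3 `CCC(C)NC(=C\C(=O)/C=C/c1ccc(O)c(OC)c1)/C=C/c1ccc(O)c(OC)c1` gives > 25000 nM, also a limit, so its true position is not known. The whole set therefore rests on one result: the limit of > 25000 nM in this assay, at which 3 of the 3 values shown sit.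

The next structure, compound 4 `C=CCNC(=C\C(=O)/C=C/c1ccc(O)c(OC)c1)/C=C/c1ccc(O)c(OC)c1`, keeps the shared core of compound 3 and puts allyl in place of sec-butyl on an amine nitrogen. The most relevant measured comparison is the one that also alters this amine substituent, a step that the two limits leave unreadable from compound 2 to compound 3. Both of its ends are limits, so it has no readable size and offers no sign of which substituents might do better. None of the compounds tested has yet given a number in this assay, so a further limit is the likeliest result. The expected change is a number no higher from compound 3 to compound 4 (the limit leaves the size open), an estimate that means no shift beyond the usual scatter. For compound 4 the estimated value is 25000 nM, with an expected range from 10000 nM to 60000 nM.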

Compound 4, half-maximal inhibitory concentration: > 25000 nM
Compound 4 was reported as a limit; the forecaster's own chance of this, stated with the estimate: 85%; the middle value sits exactly at the limit.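

Compound 4 is reported only as a limit, so the steps to it from compound 2 and compound 3 cannot be read. The set still rests on a single result: the limit of > 25000 nM in this assay, at which 4 of the 4 values shown sit.

The compounds shown leave open how strong any of them truly is, and whether any substituent on the amine nitrogen would give a measured number in this assay.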